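From hydroxy to ethoxy on compound 2

This account rests on a few compounds, and the source may have more. Where it says the series, first, only, none or still open, it means among the compounds named here.

Among the measured compounds shown here, in a functional assay on KBVIN cells (Homo sapiens) for cytotoxicity, read by sulforhodamine B assay, with a stated time of 3 days (a lower number here means that less compound is needed, a higher number that more compound is needed for the effect), compound 1 (`Cc1coc(-c2ccc3c(c2O)CCCC3(C)C)c1C(=O)O`) reads 4.7 uM and compound 2 (`Cc1coc(-c2ccc3c(c2O)CCCC3(C)C)c1CO`) reads 19.9 uM as the higher of the only two numbers so far. Compound 3 (`CCOc1c(-c2occ(C)c2CO)ccc2c1CCCC2(C)C`) carries ethyl in place of hydrogen on an oxygen on an aromatic ring. For the measured compounds named here, the one measured step (a 4.2-fold higher number from compound 1 to compound 2 (0.63 log units; beyond the scatter)) was modest and lay elsewhere on the molecule, so it offers only a loose guide, and no measurement yet touches this oxygen. No shift beyond the scatter is therefore expected in this assay, and the estimated step is small (a 1.2-fold lower number from compound 2 to compound 3 (0.09 log units; within the scatter)). Compound 3 is expected near 16 uM within an estimated range from 6 uM to 40 uM for now.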

Compound 3, concentration for half-maximal effect: 15.3 uM
Estimate against measurement, compound 3: 1.0-fold (0.02 log units) above; low and high end bracket the measured number.
By their numbers in this assay, from the lowest: compound 1; then compounds 3 and 2 (each within the scatter of the next).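

Among the compounds shown here, this is the first reading at the oxygen on the aromatic ring. In this assay putting ethyl in place of the hydrogen gives a 1.3-fold lower number from compound 2 to compound 3 (0.11 log units; within the scatter) and so leaves the number within the scatter, which means this hydroxy hydrogen can be replaced without a measurable change in this assay. No supporting measurement here explains why the number holds.

On these data alone, whether a longer chain or an amine on this oxygen would also leave the number unchanged stays open. So does whether the same ethyl change would read alike on compound 1, which carries carboxy in place of hydroxymethyl.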